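Hydroxy to methoxy on compound 3

The source may hold more compounds than are shown below. What is called first, only, known or untested is meant among the compounds shown, and "the series" means these compounds.

Among the measured compounds shown here, compound 3 (`O=C(Nc1ccc(Sc2nc3ccccc3s2)c(Cl)c1)c1cccc(Br)c1O`) gives 32000 nM in a functional assay on HT-29 cells (Homo sapiens) for inhibition, read by crystal violet staining and colony formation, with stated times of 72 h and 7 days (a lower number here means that less compound is needed, a higher number that more compound is needed for the effect), and stands with compound 1 at the high end of the numbers so far. Compound 1 (`COc1ccc(S(=O)(=O)Nc2ccc3oc(-c4ccc(NC(=O)c5cccc(C)c5[N+](=O)[O-])cc4)nc3c2)cc1`) gives 26000 nM (within the scatter of compound 3). Compound 2 (`COc1ccc(S(=O)(=O)Nc2ccc3oc(-c4ccc(NC(=O)c5ccc(Cl)s5)cc4)nc3c2)cc1`) gives 2300 nM and is well clear of both.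

Compound 4 (`COc1c(Br)cccc1C(=O)Nc1ccc(Sc2nc3ccccc3s2)c(Cl)c1`) differs from compound 3 by methyl in place of hydrogen on an oxygen on an aromatic ring and the change reads as hydroxy to methoxy. For the measured compounds named here, the only measured step is an 11-fold lower number from compound 1 to compound 2 (1.05 log units; beyond the scatter) and it is large, but it swaps 3-methyl-2-nitrophenyl for 5-chlorothiophen-2-yl on a carbonyl carbon on the core of compound 1. Going by the values given here, no measured step touches the hydroxy group, so it gives neither a size nor a direction for this change. In this assay the expected result is therefore no shift beyond the scatter, with a 1.1-fold higher number from compound 3 to compound 4 (0.04 log units; within the scatter) as the estimated step. For compound 4 the estimated value is 35000 nM within an expected range of 12000 nM to 100000 nM for now.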

Compound 4, half-maximal effective concentration: 27000 nM
The estimate for compound 4 lay 1.3-fold (0.11 log units) above the measured number; the range from low to high includes it.
By their numbers in this assay, from the lowest: compound 2; then compounds 1, 4 and 3 (each within the scatter of the next).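

In this assay, among the compounds shown here, methyl in place of hydrogen on the oxygen on an aromatic ring gives a first measured step at this position (a 1.2-fold lower number from compound 3 to compound 4 (0.07 log units; within the scatter)). Hydroxy to methoxy therefore leaves the number within the scatter on this core, and the hydrogen on that oxygen is not required to keep it there, while the methyl brings no gain towards the number of compound 2. Nothing measured here accounts for this result.

Still open, going by these compounds, is whether a different group on this oxygen, such as a longer chain like ethyl or a chain ending in an amine or a carboxylic acid, would move the number beyond the scatter. Also open, on these data alone, is whether hydroxy to methoxy would be just as silent on another core.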